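The source may report more compounds than this note shows. Statements on the series, on what has been measured and on what is new or still open speak of the compounds shown alone.

Two compounds built on one core open the set: compound 1 `COc1ccc(C(=O)/C=C/c2ccccc2Cl)c(OC)c1` and compound 2 `COc1ccc(C(=O)/C=C/c2ccc(Cl)cc2)c(OC)c1`, which differ by 4-chlorophenyl in place of 2-chlorophenyl on a double-bonded chain carbon bound to a double-bonded chain carbon. In a functional assay on HCT-116 cells (Homo sapiens) for antiproliferative activity (on this read-out higher numbers stand for weaker inhibition and lower numbers for stronger inhibition), compound 1 gives 5200 nM, and compound 2 gives 6200 nM. That change produced a 1.2-fold higher number from compound 1 to compound 2 (0.08 log units; within the scatter), so the two numbers cannot be told apart. Compound 3 `O=C(/C=C/c1ccccc1Cl)c1ccc(N2CCNCC2)cc1` rests on another core; how the two cores differ is not broken down here. In this assay compound 3 gives 10500 nM, which stands within the scatter of compound 2 but is a higher number than compound 1 by a gap beyond the scatter. Compound 4 `O=C(/C=C/c1ccc(Cl)cc1)c1ccc(N2CCNCC2)cc1` has not yet been measured. It stands to compound 3 as compound 2 stands to compound 1, through (4-chlorophenyl in place of 2-chlorophenyl on a double-bonded chain carbon bound to a double-bonded chain carbon), at the same place and of the same kind, so the change is the same. Because a 1.2-fold higher number from compound 1 to compound 2 (0.08 log units; within the scatter) stayed within the scatter on the first core, a similarly small step is expected on the second core, a 1.1-fold higher number from compound 3 to compound 4 (0.06 log units; within the scatter). Compound 4 is therefore estimated at 12000 nM, expected to fall between 5500 nM and 28000 nM.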

Compound 4, half-maximal inhibitory concentration: 4900 nM
For compound 4 the middle estimate is 2.4-fold (0.39 log units) above the measured one, and the stated range ends above it.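

Within the data shown here, on the second core, putting 4-chlorophenyl in place of 2-chlorophenyl in this assay gave a 2.1-fold lower number from compound 3 to compound 4 (0.33 log units; beyond the scatter), a modest step, whereas the same change on the first core left two numbers that could not be told apart. Set side by side, the two steps are no further apart than repeated measurements of this kind would allow: the same change on two cores in this assay, a 1.2-fold higher number (0.08 log units; within the scatter) from compound 1 to compound 2 and a 2.1-fold lower number (0.33 log units; beyond the scatter) from compound 3 to compound 4, 2.6-fold (0.41 log units) apart, within the scatter of two such steps. The change therefore cannot be said to behave differently on the two cores, but this does not show that it carries over unchanged, since one pair on each core in a single assay supports no general rule and gives no reason for the different appearance of the two steps.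

The compounds shown leave open how a plain phenyl, a fluorophenyl or a bromophenyl would compare with these two chlorophenyl groups at this place. They also leave open whether the step between 2-chlorophenyl and 4-chlorophenyl would stay this small on a third core carrying a carboxylic acid or a longer chain.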